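Phenethyl to 4-Chlorophenoxy: Expected Cytotoxicity of Compound 3

The compounds below may be only part of what the source reports. "The series", "measured", "known", "first", "only" and "open" are said of these compounds alone.

Measured so far:
compound 1 `COc1ccc(Oc2ccc3c(NCCCNCc4ccco4)ccnc3c2)cc1` — 5300 nM
compound 2 `c1ccc(CCc2ccc3c(NCCCNCc4ccco4)ccnc3c2)cc1` — 16000 nM

Of the compounds shown here, two have been measured in an ADME assay on HepG2 cells (Homo sapiens) for cytotoxicity, read by luminescence, CellTiter-Glo and ATP content, with a stated time of 72 h; a higher number here means that more compound is needed for the effect, a lower number that less compound is needed. Going by the values given here, compound 2 `c1ccc(CCc2ccc3c(NCCCNCc4ccco4)ccnc3c2)cc1` stands highest of the two; its only neighbour, compound 1 `COc1ccc(Oc2ccc3c(NCCCNCc4ccco4)ccnc3c2)cc1`, sits lower, and the step between them is a 3.0-fold higher number from compound 1 to compound 2 (0.48 log units; beyond the scatter). Compound 3 `Clc1ccc(Oc2ccc3c(NCCCNCc4ccco4)ccnc3c2)cc1` has not been measured. It differs from compound 2 in one place: 4-chlorophenoxy in place of phenethyl on an aromatic carbon. Among the compounds with values here, the one measured step that bears on this change is a 3.0-fold higher number from compound 1 to compound 2 (0.48 log units; beyond the scatter), which runs the opposite way, 4-methoxyphenoxy giving way to phenethyl with a rise in the number. On these data alone, compound 3 brings back a phenoxy group, 4-chlorophenoxy in this case, so a step of roughly that size back toward lower numbers is expected; the difference between 4-chlorophenoxy and 4-methoxyphenoxy itself is untested by any measured pair. Compound 3 is therefore expected to give about 6000 nM, within 2500 nM to 15000 nM. This corresponds to an expected 2.7-fold lower number from compound 2 to compound 3 (0.43 log units; beyond the scatter).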

Compound 3, half-maximal effective concentration: 7800 nM
The estimate for compound 3 lay 1.3-fold (0.11 log units) below the measured number, and the stated range covers the measured number.
By their numbers in this assay, from the lowest: compounds 1 and 3 (each within the scatter of the next); then compound 2.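

In this assay, putting 4-chlorophenoxy in place of phenethyl on this aromatic carbon gives a 2.1-fold lower number from compound 2 to compound 3 (0.31 log units; beyond the scatter) and so shows a second phenoxy compound standing apart from compound 2. Exchanging methoxy for chloro gives a 1.5-fold higher number from compound 1 to compound 3 (0.17 log units; within the scatter) and leaves compound 1 and compound 3 unresolved, so this one change on the phenoxy group does not separate them in this assay, while phenethyl in compound 2 stays apart from both. No supporting measurement is available to explain these differences.

The compounds shown leave open whether the lower numbers belong to the phenoxy group as such, which an unsubstituted phenoxy or an anilino group could test. They also leave open how far a nitrile or a carboxylic acid in place of chloro would move the number.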